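Fluoro on the aromatic ring of compound 3: expected cytotoxicity

A few compounds are considered here, and "the series" means these few. Any claim that something is new, unique, unknown or untested is made for them only; others in the source may bear on it.

Three compounds of the series have a number in an ADME assay on HEp-2 cells (Homo sapiens) for cytotoxicity, read by MTT assay, with a stated time of 3 days (on this read-out higher numbers stand for lower toxicity in this test and lower numbers for higher toxicity in this test), so far. Compound 1 `CC[C@H](CCn1cncn1)c1ccccc1` gives 97.7 ug/mL in this assay. Compound 2 `CC[C@H](CCn1cncn1)c1ccc(F)cc1` gives 103 ug/mL in this assay. Compound 3 `CCC[C@H](CCn1cncn1)c1ccccc1` gives 58.4 ug/mL in this assay. Compound 3 has the lowest of the three numbers, but both other values sit within the scatter of it, so no order among the three can be read from these figures.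

Compound 4 `CCC[C@H](CCn1cncn1)c1ccc(F)cc1` is not yet measured. Relative to compound 3 the change is fluoro in place of hydrogen on an aromatic carbon. The same change has been made once before in the series, on compound 1, where the result was a 1.1-fold higher number from compound 1 to compound 2 (0.02 log units; within the scatter). The other measured step, a 1.7-fold lower number from compound 1 to compound 3 (0.22 log units; within the scatter), shows that the chain difference separating the pair of compounds 1 and 2 from the pair of compounds 3 and 4 also moved the number only within the scatter. With both steps inside the scatter, the step for compound 4 is expected to be a 1.1-fold higher number from compound 3 to compound 4 (0.03 log units; within the scatter), that is, no change beyond the scatter. Compound 4 is therefore estimated at 62 ug/mL, with a range from 35 ug/mL to 110 ug/mL.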

Compound 4, half-maximal cytotoxic concentration: 39.3 ug/mL
Compound 4: middle estimate off by 1.6-fold (0.20 log units), on the high side; low and high end bracket the measured number.
By their numbers in this assay, from the lowest: compounds 4, 3, 1 and 2 (each within the scatter of the next, the first and the last beyond it).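

In this assay, going by these compounds alone, fluoro in place of hydrogen on an aromatic carbon, para to a large group, now has a second reading on a second core, a 1.5-fold lower number from compound 3 to compound 4 (0.17 log units; within the scatter), and the two readings agree: the same change on two cores in this assay, a 1.1-fold higher number (0.02 log units; within the scatter) from compound 1 to compound 2 and a 1.5-fold lower number (0.17 log units; within the scatter) from compound 3 to compound 4, 1.6-fold (0.19 log units) apart, within the scatter of two such steps The methyl in place of hydrogen on a saturated chain carbon, three bonds along the chain from an aromatic carbon, now gives the first step beyond the scatter, though only a modest one, a 2.6-fold lower number from compound 2 to compound 4 (0.42 log units; beyond the scatter), and it still matches the same change made without the fluoro: the same change on two cores in this assay, a 1.7-fold lower number (0.22 log units; within the scatter) from compound 1 to compound 3 and a 2.6-fold lower number (0.42 log units; beyond the scatter) from compound 2 to compound 4, 1.6-fold (0.19 log units) apart, within the scatter of two such steps Neither change therefore shows a size that depends on the other, and the one gap beyond the scatter for a single change lies on the chain carbon, not on the aromatic carbon.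

Fluoro is the only group shown on this aromatic carbon, so a chloro, a methoxy or an amine there could read either way in this assay. Methyl is likewise the only chain change shown, which leaves open whether a chain longer than that of compound 4 would extend the step beyond the scatter or level off.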